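Sulfonamide heteroaryl swap on the cyanopyrrole acetamide series

The compounds below may be only part of what the source reports. "The series", "measured", "known", "first", "only" and "open" are said of these compounds alone.

Measured so far:
compound 1 `N#Cc1c(-c2ccccc2)cn(-c2ccc(S(=O)(=O)Nc3ccccn3)cc2)c1NC(N)=O` gives 7340 nM in a functional assay on MCF7 cells (Homo sapiens) for inhibition, read by sulforhodamine B assay, with a stated time of 24 h; on this read-out higher numbers stand for weaker inhibition and lower numbers for stronger inhibition
compound 2 `CC(=O)Nc1c(C#N)c(-c2ccccc2)cn1-c1ccc(S(=O)(=O)Nc2nccs2)cc1` gives 7240 nM in this assay

Going by the values given here, compound 1 and compound 2 differ in two places at once, the amide on the core and the heteroaryl on the sulfonamide nitrogen, so no single step between them can be read. Compound 2 sits at the lower of the two values, but the gap to compound 1 is inside the scatter, and the two numbers are best treated as the same.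

Compound 3 `CC(=O)Nc1c(C#N)c(-c2ccccc2)cn1-c1ccc(S(=O)(=O)Nc2ccccn2)cc1` keeps the acetamide of compound 2 and carries the change (pyridin-2-yl in place of 1,3-thiazol-2-yl on a sulfonamide nitrogen). Among the compounds with values here, the resulting sulfonamide is the one already present in compound 1, which with a urea in place of the acetamide gives 7340 nM, a value indistinguishable from that of compound 2. Nothing in the series points to a step beyond the scatter in this assay in either direction.

Compound 3 is therefore expected to land near 7500 nM, within 3500 nM to 16000 nM. The expected step from compound 2 to compound 3, a 1.0-fold higher number from compound 2 to compound 3 (0.02 log units; within the scatter), is estimated as essentially flat.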

Compound 3, half-maximal inhibitory concentration: 11800 nM
Beside the measured number, compound 3's estimate is 1.6-fold (0.20 log units) below it; the measured number falls inside the stated range.
By their numbers in this assay, from the lowest: compounds 2, 1 and 3 (each within the scatter of the next).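

In this assay the sulfonamide nitrogen now has its first one-place comparison, and a 1.6-fold higher number from compound 2 to compound 3 (0.21 log units; within the scatter) stays inside the scatter, so pyridin-2-yl and 1,3-thiazol-2-yl on this nitrogen cannot be told apart on this read-out while the acetamide is kept. Compound 3 also isolates the other change folded into the earlier pair: a 1.6-fold higher number from compound 1 to compound 3 (0.21 log units; within the scatter) for methyl in place of amino on a carbonyl carbon is likewise within the scatter, and the direct step between compound 1 and compound 2 still cannot be read, as they differ in two places. Nothing available explains these small differences or tests them independently of this read-out.

Going by these compounds, the three compounds cover only two aromatic heterocycles on the sulfonamide nitrogen and two small groups on the carbonyl, so it remains open whether a pyrimidin-2-yl ring or a plain methyl on that nitrogen would produce a step beyond the scatter. On these data alone, it also remains open whether a longer chain such as propyl on the carbonyl carbon would leave the values as close as these.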